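The source may report more compounds than this note shows. Statements on the series, on what has been measured and on what is new or still open speak of the compounds shown alone.

Compounds measured in an assay on isolated protein for antagonist activity at Bile acid receptor (Homo sapiens), read by TR-FRET, with a stated time of 20 min; a lower number here means a stronger inhibitor, a higher number a weaker inhibitor:
- compound 1, `Cc1ccc(-c2nn(-c3cccc(Cl)c3)cc2C(=O)Nc2ccc(C)c(S(=O)(=O)N3CCOCC3)c2)cc1` — 10.4 nM
- compound 2, `Cc1ccc(-c2nn(C(C)C)cc2C(=O)Nc2ccc(C)c(S(=O)(=O)N3CCOCC3)c2)cc1` — 49.1 nM
- compound 3, `CCCCn1cc(C(=O)Nc2ccc(C)c(S(=O)(=O)N3CCOCC3)c2)c(-c2ccc(C)cc2)n1` — 52.5 nM

Compound 3 gives the highest number of the three in this assay. It stands close to compound 2, the two differing only within the scatter, as the step of a 1.1-fold higher number from compound 2 to compound 3 (0.03 log units; within the scatter) shows. Compound 1 stands well apart: the step of a 5.0-fold higher number from compound 1 to compound 3 (0.70 log units; beyond the scatter) lies beyond the scatter, as does a 4.7-fold higher number from compound 1 to compound 2 (0.67 log units; beyond the scatter).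

Compound 4, `Cc1ccc(-c2nn(Cc3ccc4ccccc4c3)cc2C(=O)Nc2ccc(C)c(S(=O)(=O)N3CCOCC3)c2)cc1`, has not yet been measured. It differs from compound 3 in one place: naphthalen-2-yl in place of propyl on a saturated chain carbon bound to an aromatic nitrogen. Read one bond further out, this is butyl giving way to (naphthalen-2-yl)methyl on the aromatic nitrogen.

For the measured compounds named here, the steps that bear on this are a 4.7-fold higher number from compound 1 to compound 2 (0.67 log units; beyond the scatter) and a 5.0-fold higher number from compound 1 to compound 3 (0.70 log units; beyond the scatter): each replaces an aromatic group on that nitrogen with a saturated chain and each raises the number by a modest but clear amount. Going by the values given here, compound 4 brings two six-membered aromatic rings back to that position, though set off by a saturated chain carbon, a placement for which no measured pair exists. Compound 4 is therefore expected to give a lower number than compound 3, with a step of about a 2.6-fold lower number from compound 3 to compound 4 (0.42 log units; beyond the scatter), and its value in this assay is estimated at 20 nM, within a range from 6 nM to 65 nM.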

Compound 4, half-maximal inhibitory concentration: 10.2 nM
Compound 4: the middle estimate sits 2.0-fold (0.29 log units) above what was measured; the measured number falls inside the stated range.
By their numbers in this assay, from the lowest: compounds 4 and 1 (each within the scatter of the next); then compounds 2 and 3 (each within the scatter of the next).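

In this assay, the result shows that an aromatic group need not stand directly on the aromatic nitrogen: (naphthalen-2-yl)methyl, with its rings carried on a saturated chain carbon, matches 3-chlorophenyl, with a 1.0-fold lower number from compound 1 to compound 4 (0.01 log units; within the scatter). Measured against the saturated groups, the change is of similar, modest size from either one, with a 5.1-fold lower number from compound 3 to compound 4 (0.71 log units; beyond the scatter) and a 4.8-fold lower number from compound 2 to compound 4 (0.68 log units; beyond the scatter). Across these four compounds the position thus divides into two pairs, with the two aromatic groups together and isopropyl and butyl together, and the two six-membered aromatic rings of naphthalen-2-yl give no separation from the single ring of 3-chlorophenyl.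

No measurement shown here accounts for this division at the aromatic nitrogen. On these data alone, it remains open how a benzyl group, a longer chain ending in phenyl, or an amine or carboxylic acid carried on the naphthalen-2-yl rings would read at this position, and whether the saturated chain carbon could itself be lengthened without moving the number away from those of compound 1 and compound 4.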